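From Fluoro to Chloro: A Halogen Swap Awaiting Measurement

The source may report more compounds than this note shows. Statements on the series, on what has been measured and on what is new or still open speak of the compounds shown alone.

Two compounds have numbers in a functional assay on SGC-7901 cells (Homo sapiens) for antiproliferative activity, read by MTT assay, with a stated time of 72 h; a lower number here means a stronger inhibitor, a higher number a weaker inhibitor. Compound 1 `Cc1nn(C)c(Oc2ccc(Cl)cc2)c1/C=N\OCc1c(Cl)c(-c2ccc(F)cc2)nn1C` gives 8110 nM, and compound 2 `COc1ccc(Oc2c(/C=N\OCc3c(Cl)c(-c4ccc(F)cc4)nn3C)c(C)nn2C)cc1` gives 2840 nM. Going by the values given here, the single step between them, a 2.9-fold lower number from compound 1 to compound 2 (0.46 log units; beyond the scatter), comes from methoxy in place of chloro on an aromatic carbon. Among the compounds with values here, compound 2 therefore stands lowest of the two numbers, with compound 1 as its only neighbour in this assay.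

Compound 3 `COc1ccc(Oc2c(/C=N\OCc3c(Cl)c(-c4ccc(Cl)cc4)nn3C)c(C)nn2C)cc1` differs from compound 2 by chloro in place of fluoro on an aromatic carbon. Within the data shown here, no measured step bears on this change: the only step available alters a different ring, and neither measured compound carries chloro in this place. With no directional evidence, the expected step is a 1.1-fold lower number from compound 2 to compound 3 (0.04 log units; within the scatter), that is, nothing beyond the scatter. Compound 3 is accordingly estimated at 2600 nM, with a range from 1000 nM to 7000 nM.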

Compound 3, half-maximal inhibitory concentration: 2010 nM
For compound 3 the middle estimate is 1.3-fold (0.11 log units) above the measured one; the measured number falls inside the stated range.
By their numbers in this assay, from the lowest: compounds 3 and 2 (each within the scatter of the next); then compound 1.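

In this assay, going by these compounds alone, the change from 4-fluorophenyl to 4-chlorophenyl gives a 1.4-fold lower number from compound 2 to compound 3 (0.15 log units; within the scatter) and is the first reading of this place, on a six-membered aromatic ring of carbon only, para to a large group. Fluoro and chloro at this place are not told apart here, whereas the change on the other ring, methoxy in place of chloro, gives a 2.9-fold lower number from compound 1 to compound 2 (0.46 log units; beyond the scatter) and so remains the only step in this series that clears the scatter. Nothing available speaks to the reason for this result.

The compounds shown leave open whether a group other than these two halogens at this place, such as trifluoromethyl or an amine, would move the number beyond the scatter. They also leave open whether the two halogens read alike when the other ring carries chloro, as in compound 1.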